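The compounds below may be only part of what the source reports. "The series", "measured", "known", "first", "only" and "open" are said of these compounds alone.

Measured so far:
compound 1, `CC1CCN(S(=O)(=O)N2CCN(CC(=O)Nc3cc(Cl)ccc3OC(C)C)CC2)CC1`: 5100 nM
compound 2, `COc1ccc(Cl)cc1NC(=O)[C@@H](C)N1CCN(S(=O)(=O)N2CCC(C)CC2)CC1`: 4900 nM

Both numbers come from an assay on HEK293 cells for inhibition of potassium channel subfamily T member 1 (Homo sapiens), read by thallium flux; on this read-out higher numbers stand for weaker inhibition and lower numbers for stronger inhibition. Compound 1 gives 5100 nM in this assay, and compound 2 gives 4900 nM; the two values lie within the scatter of each other, so neither compound can be placed above the other, and compound 1 holds the higher of the two numbers only nominally. Within the data shown here, compound 2 differs from compound 1 in more than one place, so no single step between them has been worked out; what the pair shows is simply that both are weak inhibitors of about the same size.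

Compound 3, `CCOc1ccc(Cl)cc1NC(=O)CN1CCN(S(=O)(=O)N2CCC(C)CC2)CC1`, has not yet been measured. It keeps the whole core of compound 1 and alters one place: hydrogen in place of methyl on a saturated chain carbon bound to an oxygen on an aromatic ring and a saturated chain carbon. Among the measured compounds shown here, no step between measured compounds bears on this change. Given how small the change is, and how close the two measured compounds sit, the expectation is that the step of a 1.1-fold higher number from compound 1 to compound 3 (0.03 log units; within the scatter) stays within the scatter, with no firm direction. Compound 3 is therefore expected to give about 5500 nM in this assay, within a range from 2500 nM to 12000 nM.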

Compound 3, half-maximal inhibitory concentration: 7100 nM
The estimate for compound 3 lay 1.3-fold (0.11 log units) below the measured number, and the stated range covers the measured number.
By their numbers in this assay, from the lowest: compounds 2, 1 and 3 (each within the scatter of the next).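

Among these compounds, the step from isopropoxy to ethoxy in this assay is the first comparison that differs in one place: a 1.4-fold higher number from compound 1 to compound 3 (0.14 log units; within the scatter). At this position, on a saturated chain carbon bound to an oxygen on an aromatic ring and a saturated chain carbon, hydrogen in place of methyl therefore leaves the two compounds indistinguishable on this read-out, a finding that holds for this one pair only. No supporting data bear on this step, and the result itself gives no account of what the methyl does or does not contribute at this place.

Still open, as far as these compounds go, is whether any group on this oxygen can produce a step beyond the scatter, for instance a longer chain such as n-butyl or a ring-bearing group such as benzyl. From the compounds shown here alone, it is equally open whether an amine or a carboxylic acid at the end of that chain would leave the number as unchanged as the ethoxy group does here, or would separate clearly from the isopropoxy group of compound 1.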